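A 4-Chlorophenyl Addition on the Amide of Compound 1

The source may report more compounds than this note shows. Statements on the series, on what has been measured and on what is new or still open speak of the compounds shown alone.

Of the compounds shown here, three sharing one core have been measured in a functional assay on COLO 205 cells (Homo sapiens) for inhibition, read by sulforhodamine B assay, with a stated time of 48 h; on this read-out lower numbers stand for stronger inhibition of growth and higher numbers for weaker inhibition of growth. Compound 1 `N#C/C(=C\N1CCN(C(=O)c2ccco2)C1=S)C(N)=O` gives 24900 nM, the highest of the three numbers. Compound 2 `COc1cc(C(=O)N2CCN(C=O)C2=S)cc(OC)c1OC` gives 20200 nM in this assay, a number that lies within the scatter of the number for compound 1. Compound 3 `O=CN1CCN(C(=O)c2ccco2)C1=S` gives 8700 nM in this assay, a lower number than compound 1 by a gap that lies beyond the scatter. For the measured compounds named here, no two of these three compounds differ in only one place, so no single-change step among measured compounds is known.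

Compound 4 `N#C/C(=C\N1CCN(C(=O)c2ccco2)C1=S)C(=O)Nc1ccc(Cl)cc1` has not yet been measured in this assay. It differs from compound 1 in one place: 4-chlorophenyl in place of hydrogen on an amide-type nitrogen. Going by the values given here, nothing among the measured compounds tells how this change behaves in this assay. For a 1.8-fold lower number from compound 1 to compound 4 (0.25 log units; within the scatter) a modest step toward stronger inhibition is expected, though with wide uncertainty. Compound 4 is therefore estimated at 14000 nM, within a range from 4000 nM to 45000 nM.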

Compound 4, concentration for 50% growth inhibition: 25600 nM
Compound 4: the middle estimate sits 1.8-fold (0.26 log units) below what was measured; the measured number falls inside the stated range.
By their numbers in this assay, from the lowest: compound 3; then compounds 2, 1 and 4 (each within the scatter of the next).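

In this assay, for the compounds shown here, the first single-change step in this set reads a 1.0-fold higher number from compound 1 to compound 4 (0.01 log units; within the scatter) and lies within the scatter. At this amide-type nitrogen, then, 4-chlorophenyl in place of hydrogen leaves the read-out where it stood, so a six-membered aromatic ring can sit here without a shift beyond the scatter, at least for this single pair. The data on hand offer no explanation for this outcome and give no cause for it.

On these data alone, whether other groups on this nitrogen, such as an unsubstituted phenyl, a longer alkyl chain, an amine or a carboxylic acid, would also stay within the scatter remains open. So does whether the same 4-chlorophenyl change would read alike on any compound other than compound 1.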